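Esters of a shared core: from isopropyl to acetylpiperidinyl

This account rests on a few compounds, and the source may have more. Where it says the series, first, only, none or still open, it means among the compounds named here.

This account concerns two measured esters and a third whose value is not yet known. Compound 1 `CC(C)C(=O)OCCc1c(-c2ccccc2Cl)c2cc(Cl)ccc2[nH]c1=O` and compound 2 `O=C(OCCc1c(-c2ccccc2Cl)c2cc(Cl)ccc2[nH]c1=O)C1CCCC1` differ only in the group on the carbonyl carbon of the ester. In an ADME assay on HepG2 2.2.15 cells (Homo sapiens) for cytotoxicity (a higher number here means that more compound is tolerated, a lower number that less compound is tolerated), compound 1 gives 62000 nM, and in this assay compound 2 gives 46000 nM. Within the data shown here, the only measured step, a 1.3-fold lower number from compound 1 to compound 2 (0.13 log units; within the scatter), shows that exchanging isopropyl for cyclopentyl leaves the read-out within the scatter, so compound 1 and compound 2 cannot be told apart on these numbers.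

Compound 3 `CC(=O)N1CCC(C(=O)OCCc2c(-c3ccccc3Cl)c3cc(Cl)ccc3[nH]c2=O)CC1` carries a different ester group. The change from compound 1 to compound 3 is 1-acetylpiperidin-4-yl in place of isopropyl on a carbonyl carbon. The step from compound 1 to compound 2 is the only one that bears on it, and it was within the scatter. Among the measured compounds shown here, no measured step tests an acetylated ring nitrogen in this position, so the expectation for compound 3 rests on the single small step seen; the change a 1.1-fold higher number from compound 1 to compound 3 (0.05 log units; within the scatter) is expected to stay within the scatter. Compound 3 is therefore estimated at 70000 nM, with a range from 30000 nM to 150000 nM.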

Compound 3, half-maximal cytotoxic concentration: 82000 nM
Beside the measured number, compound 3's estimate is 1.2-fold (0.07 log units) below it, and the stated range covers the measured number.
By their numbers in this assay, from the lowest: compounds 2, 1 and 3 (each within the scatter of the next).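

Where the earlier pair had only set one all-carbon group against another on the carbonyl carbon, compound 3 puts a six-membered non-aromatic ring with a nitrogen and an acetyl group in that place, and a 1.3-fold higher number from compound 1 to compound 3 (0.12 log units; within the scatter) in this assay remains within the scatter. Set against the cyclopentyl ester, the same group gives a 1.8-fold higher number from compound 2 to compound 3 (0.25 log units; within the scatter) and is again within the scatter, so isopropyl, cyclopentyl and 1-acetylpiperidin-4-yl cannot be told apart here, even though the entering group adds a hydrogen-bond acceptor and a hetero atom. No measurement is available that would explain this result.

The three compounds leave open whether the read-out would stay within the scatter with a free secondary amine in place of the acetylated ring nitrogen, or with a carboxylic acid on the ring. They also say nothing about a longer open chain on the carbonyl carbon, or about any change to the shared core, since all three esters carry that core unaltered.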